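Phenyl to benzyl on an aromatic nitrogen

The source may hold more compounds than are shown below. What is called first, only, known or untested is meant among the compounds shown, and "the series" means these compounds.

Compound 1 `CCCCc1ccc(-c2c(C)[nH]c(=O)n2C)cc1` gives 10700 nM
Compound 2 `CCCCc1ccc(-c2c(C)[nH]c(=O)n2CCCC)cc1` gives 12000 nM
Compound 3 `CCCCc1ccc(-c2c(C)[nH]c(=O)n2-c2ccccc2)cc1` gives 16600 nM

These values come from a functional assay on brain (Rattus norvegicus, strain Wistar) for inhibition; on this read-out lower numbers stand for stronger inhibition and higher numbers for weaker inhibition. Compound 3 stands within the scatter of compound 1 and compound 2. Compound 4 `CCCCc1ccc(-c2c(C)[nH]c(=O)n2Cc2ccccc2)cc1` keeps the shared core and changes only the group on the aromatic nitrogen (benzyl in place of phenyl on an aromatic nitrogen). The measured changes at that same group were all small (a 1.1-fold higher number from compound 1 to compound 2 (0.05 log units; within the scatter); a 1.6-fold higher number from compound 1 to compound 3 (0.19 log units; within the scatter); a 1.4-fold higher number from compound 2 to compound 3 (0.14 log units; within the scatter)), so no step beyond the scatter is expected in this assay, in either direction. The expected step is small (a 1.3-fold lower number from compound 3 to compound 4 (0.12 log units; within the scatter)). Compound 4 is estimated at 12500 nM (expected range 6500 nM to 23000 nM).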

Compound 4, half-maximal inhibitory concentration: 12400 nM
Compound 4: the middle estimate sits 1.0-fold (0.00 log units) above what was measured; the range from low to high includes it.
By their numbers in this assay, from the lowest: compounds 1, 2, 4 and 3 (each within the scatter of the next).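

In this assay benzyl in place of phenyl gives a 1.3-fold lower number from compound 3 to compound 4 (0.13 log units; within the scatter) and compound 4 also compares with the two chain-bearing compounds as a 1.0-fold higher number from compound 2 to compound 4 (0.01 log units; within the scatter) and a 1.2-fold higher number from compound 1 to compound 4 (0.06 log units; within the scatter) with all three steps within the scatter. On this aromatic nitrogen, a phenyl ring held on a saturated chain carbon therefore reads the same as a phenyl ring bound directly, and the same as methyl or butyl. Nothing measured bears on why the read-out stays flat here. Going by these compounds, whether an amine or a carboxylic acid on this nitrogen would produce a step beyond the scatter remains open.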